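Trifluoromethylcarbonyl for tosyl on an amine nitrogen

The source may hold more compounds than are shown below. What is called first, only, known or untested is meant among the compounds shown, and "the series" means these compounds.

Measured compounds: compound 1 `Cc1ccc(S(=O)(=O)n2cc(CN(Cc3cccc(F)c3F)C(=O)C(F)(F)F)c3ccccc32)cc1` gives -5.5%; compound 2 `Cc1ccc(S(=O)(=O)N(Cc2cccc(F)c2F)Cc2cn(S(=O)(=O)c3ccc(C)cc3)c3ccccc23)cc1` gives -13.9%; compound 3 `Cc1ccc(S(=O)(=O)N(Cc2cn(Cc3cccc(F)c3F)nn2)Cc2cn(S(=O)(=O)c3ccc(C)cc3)c3ccccc23)cc1` gives 71.5%.

In a functional assay on 3T3-L1 cells (Mus musculus) for inhibition, with a stated time of 20 min, tested at 20 uM (a lower number here means less inhibition, a higher number more inhibition at the concentration tested (going by the name of the read-out)), compound 3 stands highest, and its gaps to compound 1 and compound 2 lie beyond the scatter. How the core of compound 3 differs from that of compound 2 is not broken down here. From compound 2 to compound 1 one group is exchanged on an amine nitrogen: (trifluoromethyl)carbonyl in place of (4-methylphenyl)sulfonyl on an amine nitrogen This gave a number 8.4 percentage points higher from compound 2 to compound 1 (within the scatter), a step within the scatter. Compound 4 `Cc1ccc(S(=O)(=O)n2cc(CN(Cc3cn(Cc4cccc(F)c4F)nn3)C(=O)C(F)(F)F)c3ccccc32)cc1` carries the same change on the core of compound 3: (trifluoromethyl)carbonyl in place of (4-methylphenyl)sulfonyl on an amine nitrogen Because the earlier step of a number 8.4 percentage points higher from compound 2 to compound 1 (within the scatter) was within the scatter, compound 4 is expected to stay near compound 3, with a step of a number 0.5 percentage points higher from compound 3 to compound 4 (within the scatter) anticipated. The estimate for compound 4 in this assay is 72%, expected between 50% and 90%.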

Compound 4, a percentage reported as inhibition, at one concentration (the size of the read-out at that concentration, not a potency): 31.9%
Compound 4: the middle estimate sits 40.1 percentage points above what was measured; the measured number lies below the stated range.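

In this assay the exchange of (4-methylphenyl)sulfonyl for (trifluoromethyl)carbonyl on an amine nitrogen did not carry over from one core to the other: the same change on two cores in this assay, a number 8.4 percentage points higher (within the scatter) from compound 2 to compound 1 and a number 39.6 percentage points lower (beyond the scatter) from compound 3 to compound 4, 48 percentage points apart, beyond the scatter of two such steps. The change gave a number 39.6 percentage points lower from compound 3 to compound 4 (beyond the scatter) and so cost much of the inhibition on that core, which means the small step on the other core was no guide to it. This rests on a single pair of steps, so it shows that the outcome of the change depends on the core but not why, nor how the change would behave on any further core.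

The compounds shown leave open whether an acetyl or a methyl group on that amine nitrogen would retain the inhibition seen with (4-methylphenyl)sulfonyl. They also leave open how these differences at one concentration relate to potency.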